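Swapping a Piperazine Tail for a Dimethylamino Tail

The source may report more compounds than this note shows. Statements on the series, on what has been measured and on what is new or still open speak of the compounds shown alone.

Compound 1 `CN1CCN(CCCCCn2c3c(c4ccccc42)C(=O)c2c[n+]([O-])c4ccccc4c2C3=O)CC1` carries a flexible chain ending in a ring-shaped amine. In a functional assay on MDA-MB-231 cells (Homo sapiens) for cytotoxicity, read by MTT assay, with a stated time of 72 h (on this read-out higher numbers stand for weaker inhibition and lower numbers for stronger inhibition), compound 1 gives 2270 nM, the highest of the three numbers measured. For the measured compounds named here, compound 2 `CC1(C)O[C@@H](CO)[C@H](Cn2cc(Cn3c4c(c5ccccc53)C(=O)c3c[n+]([O-])c5ccccc5c3C4=O)nn2)O1` gives 680 nM, and compound 3 `O=C1c2c[n+]([O-])c3ccccc3c2C(=O)c2c1c1ccccc1n2Cc1cn([C@@H]2C[C@H](O)[C@@H](CO)O2)nn1` gives 130 nM; the one single-point step, a 5.2-fold lower number from compound 2 to compound 3 (0.72 log units; beyond the scatter), concerns a sugar-like group and says nothing about the amine tail. Compound 4 `CN(C)CCCCCn1c2c(c3ccccc31)C(=O)c1c[n+]([O-])c3ccccc3c1C2=O` differs from compound 1 only at that tail: dimethylamino in place of 4-methylpiperazin-1-yl on a saturated chain carbon, five bonds along the chain from an aromatic nitrogen. Going by the values given here, no measured step bears on this exchange, so the expectation rests on the value of compound 1 alone. The expected change is a 1.1-fold lower number from compound 1 to compound 4 (0.05 log units; within the scatter), judged to stay within the usual scatter. Compound 4 is estimated at 2000 nM, with a range from 700 nM to 6000 nM.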

Compound 4, half-maximal inhibitory concentration: 240 nM
Estimate against measurement, compound 4: 8.3-fold (0.92 log units) above, and the stated range ends above it.
By their numbers in this assay, from the lowest: compounds 3 and 4 (each within the scatter of the next); then compound 2; then compound 1.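

The amine at the end of the chain turns out to matter: in this assay, placing dimethylamino where 4-methylpiperazin-1-yl stood gives a 9.5-fold lower number from compound 1 to compound 4 (0.98 log units; beyond the scatter). The earlier compounds shown here carried no such pair, so only now is this tail seen to affect the read-out, with the smaller, ring-free amine giving stronger inhibition. No available evidence accounts for this step.

As far as these compounds go, whether losing the ring or simply losing size matters more remains open. A pyrrolidin-1-yl or diethylamino tail, or dimethylamino on a longer chain, would help separate these.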